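This account rests on a few compounds, and the source may have more. Where it says the series, first, only, none or still open, it means among the compounds named here.

Compound 1 `CNC(=O)c1cc(Oc2ccc3nc(NC(=O)c4ccc(Cl)cc4Cl)sc3c2)ccn1`: 14%
Compound 2 `CNC(=O)c1cc(Oc2ccc3nc(NC(=O)Nc4ccc(N5CCN(C)CC5)cc4)sc3c2)ccn1`: 30.5%

In a functional assay on SK-BR-3 cells (Homo sapiens) for inhibition, read by MTT assay, with a stated time of 2 days, tested at 10 uM (on this read-out higher numbers stand for more inhibition of growth at the one concentration tested and lower numbers for less inhibition of growth), compound 1 gives 14%, the lower of the two numbers; compound 2 gives 30.5%, a gap beyond the scatter. Compound 3 `CNC(=O)c1cc(Oc2ccc3nc(NC(=O)c4cccc(F)n4)sc3c2)ccn1` differs from compound 1 by 6-fluoropyridin-2-yl in place of 2,4-dichlorophenyl on a carbonyl carbon. Within the data shown here, no measured pair shows how such an exchange acts here, so the direction is open. The expected step from compound 1 to compound 3 is a number 1 percentage points higher from compound 1 to compound 3 (within the scatter), a small shift that is not expected to go beyond the scatter. Compound 3 is therefore estimated at 15%, with a range from 0% to 35%.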

Compound 3, percent growth inhibition at one concentration: 12.5%
Compound 3: middle estimate off by 2.5 percentage points, on the high side, within the range that was stated.
By their numbers in this assay, from the lowest: compounds 3 and 1 (each within the scatter of the next); then compound 2.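

In this assay, putting 6-fluoropyridin-2-yl in place of 2,4-dichlorophenyl on a carbonyl carbon gives a step of a number 1.5 percentage points lower from compound 1 to compound 3 (within the scatter). At this position, then, a ring with both chlorines and a ring with one fluorine and a ring nitrogen cannot be told apart on this read-out. No measurement shown bears on why the two rings read alike.

Going by these compounds, what a non-aromatic group in this place, such as a morpholine ring or a short chain ending in an amine, would do remains open. One exchange between two aromatic rings cannot show how far this position tolerates change.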